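A few compounds are considered here, and "the series" means these few. Any claim that something is new, unique, unknown or untested is made for them only; others in the source may bear on it.

Of the compounds shown here, three of a shared core have so far been tested in an ADME assay on microsomes from liver (Homo sapiens) for metabolic stability; a lower number here means slower removal, a higher number faster removal of the compound. Compound 1 `Nc1ncc(-c2cc(N3C[C@@H]4C[C@H]3CO4)nc(N3CC4CC3C4)n2)nc1OC(F)F` gives 7.8 mL/min/kg. Compound 3 `CSc1cc(-c2cnc(N)c(OC(F)F)n2)nc(N2C[C@@H]3C[C@H]2CO3)n1` gives 5.7 mL/min/kg. Compound 2 `CCOC(=O)N1C[C@@H]2C[C@H]1CN2c1nc(SC)cc(-c2cnc(N)c(OC(F)F)n2)n1` gives 12.3 mL/min/kg, the highest of the three numbers; its gap to compound 1 lies within the usual scatter of the measurement, while its gap to compound 3 lies beyond it, so only against compound 3 can compound 2 be called the faster-cleared one.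

The step from compound 2 leads to compound 4 `CCOC(=O)N1C[C@@H]2C[C@H]1CN2c1nc(-c2cnc(N)c(OC(F)F)n2)cc(N2CC3CC2C3)n1`. The change is a group of 6 heavy atoms (5 carbon, 1 nitrogen; one four-membered non-aromatic ring of carbon only, one five-membered non-aromatic ring with 1 hetero atom) in place of a group of 2 heavy atoms (1 carbon, 1 sulfur; no ring), on an aromatic carbon. Among the measured compounds shown here, no pair of already measured compounds differs in exactly this one place, so the step cannot be read off directly. Compound 1, which carries the entering group, and compound 3, which carries the leaving methylsulfanyl, show values within the scatter of each other, so their numbers give no sign of a large shift in either direction. In this assay the step from compound 2 to compound 4 is therefore expected to be small, a 1.1-fold lower number from compound 2 to compound 4 (0.05 log units; within the scatter), none beyond the scatter. Compound 4 is estimated at 11 mL/min/kg, with a range from 6 mL/min/kg to 20 mL/min/kg.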

Compound 4, clearance: 11.1 mL/min/kg
Compound 4: middle estimate off by 1.0-fold (0.00 log units), on the low side; measured number inside the range.
By their numbers in this assay, from the lowest: compounds 3, 1, 4 and 2 (each within the scatter of the next, the first and the last beyond it).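

Among the compounds shown here, compound 2 and compound 4 give the first direct reading at this position, the aromatic carbon next to the ring nitrogen, with the rest of the molecule unchanged. In this assay, putting the group of 6 heavy atoms, with its four-membered and five-membered rings, in place of methylsulfanyl gives a 1.1-fold lower number from compound 2 to compound 4 (0.04 log units; within the scatter) and leaves the two compounds indistinguishable, so for this pair a much larger group at this carbon brings no measurable difference in clearance. Nothing available here says why the two groups give such similar numbers, and this single pair cannot show whether the result holds elsewhere in the series.

On these data alone, it remains open whether the same exchange would also go unnoticed in compounds carrying the oxygen-containing bridged ring found in compound 1 and compound 3 instead of the ring system with the ethyl ester of compound 2 and compound 4. Also open, as far as these compounds go, is how clearance would respond at this aromatic carbon to quite different groups, such as a methoxy group, a simple open-chain amine like dimethylamino, or a carboxylic acid.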